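This account rests on a few compounds, and the source may have more. Where it says the series, first, only, none or still open, it means among the compounds named here.

Compound 2 `N#C/C(=C\c1c[nH]c2cc(F)ccc12)C(=O)c1c[nH]c2cc(F)ccc12` is the starting point of this account. In a functional assay on PC-3 cells (Homo sapiens) for cytotoxicity, read by WST assay, with a stated time of 24 h (a lower number here means a stronger inhibitor, a higher number a weaker inhibitor), compound 2 reaches only the limit of the assay, > 50000 nM, and no number. Compound 1 `COc1ccc(Cn2cc(/C=C(\C#N)C(=O)c3c[nH]c4cc(OC)ccc34)c3ccccc32)cc1` is likewise known only as a limit in this assay, giving > 50000 nM. Compound 3 `COc1ccc2c(/C=C(\C#N)C(=O)c3c[nH]c4cc(F)ccc34)c[nH]c2c1` also sits at a limit in this assay, with > 50000 nM. Within the data shown here, the one change that can be compared in one place, methoxy in place of fluoro on an aromatic carbon, gives a step that the two limits leave unreadable from compound 2 to compound 3, so the size of that step cannot be read. The whole picture so far is the limit of > 50000 nM in this assay, at which 3 of the 3 values shown sit. Compound 4 `N#C/C(=C\c1c[nH]c2cc(F)ccc12)C(=O)c1c[nH]c2ccccc12` differs from compound 2 by hydrogen in place of fluoro on an aromatic carbon. Among the measured compounds shown here, no measured step bears directly on this change, and the only step that is known at all is unreadable, so no step beyond the scatter in this assay is expected in either direction, and the most likely outcome is that compound 4 again returns only a limit. Compound 4 is therefore estimated at 70000 nM, with a range from 20000 nM to 250000 nM. This estimate means an expected step that the limit leaves unreadable from compound 2 to compound 4.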

Compound 4, half-maximal inhibitory concentration: > 50000 nM
Compound 4 was reported as a limit (the forecaster's own chance of this, stated with the estimate: 80%); the middle value is on the limit's open side.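

Compound 4, like compound 2, is known in this assay only as a limit, so no step can be read from the change of fluoro to hydrogen. The compounds shown leave open which change, if any, to the shared core would give a readable value: the limit of > 50000 nM in this assay, at which 4 of the 4 values shown sit.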